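This account rests on a few compounds, and the source may have more. Where it says the series, first, only, none or still open, it means among the compounds named here.

Measured compounds:
compound 1 `O=C(Nc1nnc(-c2ccccc2)s1)c1cc(Br)ccc1O` — 1280 nM
compound 2 `O=C(Nc1nnc(-c2ccc(F)cc2)s1)c1cc(Br)ccc1O` — 860 nM
compound 3 `O=C(Nc1nnc(-c2ccccc2)s1)c1ccccc1` — 5870 nM

The three measured compounds were tested in a functional assay on MCF7 cells (Homo sapiens) for antiproliferative activity, read by MTT assay, with a stated time of 48 h; on this read-out higher numbers stand for weaker inhibition and lower numbers for stronger inhibition. Compound 1 and compound 2 share one core and differ in a single place: fluoro in place of hydrogen on an aromatic carbon The step this made is a 1.5-fold lower number from compound 1 to compound 2 (0.17 log units; within the scatter). Compound 3 carries a different core; the difference between the two cores is not broken down here. In this assay compound 3 gives 5870 nM, the highest number of the three, with compound 1 at 1280 nM as its nearest neighbour and compound 2 at 860 nM as the furthest.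

Compound 4 `O=C(Nc1nnc(-c2ccc(F)cc2)s1)c1ccccc1` has not yet been measured. It differs from compound 3 in one place: fluoro in place of hydrogen on an aromatic carbon This is the same change as from compound 1 to compound 2, on the same kind of place, para to a large group on a six-membered aromatic ring of carbon only. The expected step is therefore taken from the measured one: compound 4 is expected to sit at 4000 nM, a step of a 1.5-fold lower number from compound 3 to compound 4 (0.17 log units; within the scatter), because the earlier change gave a 1.5-fold lower number from compound 1 to compound 2 (0.17 log units; within the scatter). The expected range for compound 4 runs from 2000 nM to 9000 nM.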

Compound 4, half-maximal inhibitory concentration: 5350 nM
Beside the measured number, compound 4's estimate is 1.3-fold (0.13 log units) below it, within the range that was stated.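

Working notes on the series: in this assay, phenyl to 4-fluorophenyl on the second core gives a 1.1-fold lower number from compound 3 to compound 4 (0.04 log units; within the scatter), a step that cannot be told from repeat measurement. Set beside the step on the first core, the change reads the same on both: the same change on two cores in this assay, a 1.5-fold lower number (0.17 log units; within the scatter) from compound 1 to compound 2 and a 1.1-fold lower number (0.04 log units; within the scatter) from compound 3 to compound 4, 1.4-fold (0.13 log units) apart, within the scatter of two such steps

This shows that, on these two cores, the change carries over as a step within the scatter; it does not show that fluoro has any real effect on either core, and with neither step beyond the scatter, it does not test whether a sizeable step would carry over, nor does a pair of cores make a rule for the series.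

Open, as far as these compounds go, is whether another group in the same place, such as an amine, a carboxylic acid or a longer chain, would give a step beyond the scatter, and whether that step would then hold on both cores. Also open is what the bromo and hydroxyl groups each contribute, as the compounds shown carry them only together.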